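This account rests on a few compounds, and the source may have more. Where it says the series, first, only, none or still open, it means among the compounds named here.

Measured compounds in the set:

Compound 1, `CN1CCN(CCCOc2cccc3nc(Nc4ccc(Cl)c(F)c4)ccc23)CC1`, gives 1760 nM.
Compound 2, `CC(C)c1ccc(Nc2ccc3c(OCCCN4CCN(C)CC4)cccc3n2)cc1`, gives 13400 nM.
Compound 3, `CN1CCN(CCCOc2cccc3nc(Nc4ccc(F)c(F)c4)ccc23)CC1`, gives 4070 nM.

All three share one core and differ only in the aryl group attached to the nitrogen on the aromatic ring; the numbers come from a functional assay on cells (Panel prostate (Carcinoma cell lines), Homo sapiens) for inhibition, read by sulforhodamine B assay, with a stated time of 48 h; on this read-out higher numbers stand for weaker inhibition of growth and lower numbers for stronger inhibition of growth. On those numbers compound 3 stands second highest of three: compound 1 is nearer, with a 2.3-fold higher number from compound 1 to compound 3 (0.36 log units; beyond the scatter), and compound 2 is further away, with a 3.3-fold lower number from compound 2 to compound 3 (0.52 log units; beyond the scatter).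

Compound 4, `CN1CCN(CCCOc2cccc3nc(Nc4cccc(Cl)c4)ccc23)CC1`, has not yet been measured. Its change from compound 3 is 3-chlorophenyl in place of 3,4-difluorophenyl on a nitrogen on an aromatic ring. For the measured compounds named here, two measured steps touch this position. The swap of a single halogen, fluoro for chloro, gave a 2.3-fold higher number from compound 1 to compound 3 (0.36 log units; beyond the scatter), a modest step. Exchanging the whole aryl group, 3,4-difluorophenyl for 4-isopropylphenyl, gave a 3.3-fold lower number from compound 2 to compound 3 (0.52 log units; beyond the scatter), also modest. Going by the values given here, no measured step removes the group at the 4-position entirely or places chloro at the 3-position, so the direction here is uncertain; the halogenated aryl groups measured so far cluster together, while the isopropyl analogue sits apart.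

Compound 4 is therefore expected to land near compound 3, with the step estimated as a 1.3-fold lower number from compound 3 to compound 4 (0.10 log units; within the scatter). The estimate for compound 4 is 3200 nM, ranging from 1100 nM to 9500 nM.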

Compound 4, concentration for 50% growth inhibition: 1900 nM
The estimate for compound 4 lay 1.7-fold (0.23 log units) above the measured number; low and high end bracket the measured number.
By their numbers in this assay, from the lowest: compounds 1 and 4 (each within the scatter of the next); then compound 3; then compound 2.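

In this assay, replacing 3,4-difluorophenyl with 3-chlorophenyl gives a 2.1-fold lower number from compound 3 to compound 4 (0.33 log units; beyond the scatter) and shows that this position tolerates a change in both the number and the kind of halogen, not only the single-halogen swap seen earlier. The comparison with compound 1 gives a 1.1-fold higher number from compound 1 to compound 4 (0.03 log units; within the scatter) as the step, so 4-chloro-3-fluorophenyl and 3-chlorophenyl read alike here: once chloro is on the ring, the extra fluoro and the different chloro placement make no difference that can be told from scatter. Both chloro compounds also read lower than compound 3, and the gap to the isopropyl analogue is wide, with a 7.1-fold lower number from compound 2 to compound 4 (0.85 log units; beyond the scatter) as the step, so among these four compounds the order runs from the chloro-bearing aryl groups through the difluoro group to the 4-isopropylphenyl group, with no compound going against it.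

The compounds shown leave open whether this order would hold for a plain phenyl group, a 3-bromophenyl group or a 3-methoxyphenyl group on the same nitrogen. Nothing measured alongside these growth-inhibition numbers accounts for the lower readings of the chloro compounds.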